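The compounds below may be only part of what the source reports. "The series", "measured", "known", "first", "only" and "open" are said of these compounds alone.

Working notes on the series. Compound 1 `COc1cc(NC(C)CCCNC(=O)NCc2ccncc2)c2ncccc2c1` has no result: in an ADME assay on L6 cells (Rattus norvegicus) for cytotoxicity, read by resazurin assay, with a stated time of 70 h (on this read-out higher numbers stand for weaker inhibition and lower numbers for stronger inhibition), compound 1 gives "not determined" (no result reported). Going by the values given here, compound 2 `COc1ccc(/C=C/C(=O)NNC(=O)NCCCC(C)Nc2cc(OC)cc3cccnc23)cc1` is the one member with a number; in this assay compound 2 gives 3600 nM, the only value so far, so it stands alone without comparison. Compound 3 `COc1cc(NC(C)CCCNC(=O)NNC(=O)Nc2cccc(C(F)(F)F)c2)c2ncccc2c1` differs from compound 2 by (3-(trifluoromethyl)phenyl)amino in place of 2-(4-methoxyphenyl)ethenyl on a carbonyl carbon. Among the compounds with values here, no measured pair frames this exchange, so in this assay a step no larger than the usual scatter is expected, in no settled direction. Compound 3 is expected at 4000 nM, between 1500 nM and 12000 nM. The step that estimate means, a 1.1-fold higher number from compound 2 to compound 3 (0.05 log units; within the scatter), is expected to stay within scatter.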

Compound 3, half-maximal inhibitory concentration: 32100 nM
Compound 3: middle estimate off by 8.0-fold (0.90 log units), on the low side, outside the stated range (above it).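

In this assay, the group on this carbonyl carbon clearly matters: (3-(trifluoromethyl)phenyl)amino in place of 2-(4-methoxyphenyl)ethenyl gives an 8.9-fold higher number from compound 2 to compound 3 (0.95 log units; beyond the scatter), a step beyond the scatter towards weaker inhibition. Going by these compounds alone, this is the first evidence that the position responds in this read-out. Nothing available explains the step. 

Going by these compounds, this single exchange changes both the link to the ring and the ring substituent, so the contribution of each remains open. Also open, on these data alone, is how a plain phenylamino group or a morpholine at this carbonyl carbon would read.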